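The source may hold more compounds than are shown below. What is called first, only, known or untested is meant among the compounds shown, and "the series" means these compounds.

Working notes on the series. The shared core carries an aromatic oxygen substituent that varies across the set: compound 1 `CCCCCCOc1ccc(C(=O)/C=C/c2c(/C=C/c3ccc(OC)cc3)cc(OC)cc2OC)cc1` with hexyl, compound 2 `CCCC(C)Oc1ccc(C(=O)/C=C/c2c(/C=C/c3ccc(OC)cc3)cc(OC)cc2OC)cc1` with 1-methylbutyl, and compound 3 `COc1ccc(/C=C/c2cc(OC)cc(OC)c2/C=C/C(=O)c2ccc(OC)cc2)cc1` with methyl. Among the measured compounds shown here, in a functional assay on A549 cells (Homo sapiens) for antiproliferative activity, read by MTT assay, with a stated time of 48 h (a higher number here means a weaker inhibitor, a lower number a stronger inhibitor), compound 3 gives 4.5 ug/mL, the lowest of the three numbers, though only the step to compound 2 lies beyond the scatter. Compound 1 gives 8.4 ug/mL in this assay, and compound 2 gives 9.4 ug/mL. The two measured steps reaching compound 3 are a 1.9-fold lower number from compound 1 to compound 3 (0.27 log units; within the scatter) and a 2.1-fold lower number from compound 2 to compound 3 (0.32 log units; beyond the scatter), while a 1.1-fold higher number from compound 1 to compound 2 (0.05 log units; within the scatter) separates the two longer chains.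

Compound 4 `CCCCCCCCCCCCOc1ccc(C(=O)/C=C/c2c(/C=C/c3ccc(OC)cc3)cc(OC)cc2OC)cc1` extends the chain further: undecyl in place of hydrogen on a saturated chain carbon bound to an oxygen on an aromatic ring. The relevant steps both show that adding chain length at this oxygen raised the number, so the expected step in this assay is a 3.3-fold higher number from compound 3 to compound 4 (0.52 log units; beyond the scatter), a higher number for compound 4, probably beyond the scatter, with some risk that the read-out reaches only a limit. Compound 4 is estimated at 15 ug/mL, within a range from 6 ug/mL to 40 ug/mL.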

Compound 4, half-maximal inhibitory concentration: 7.9 ug/mL
The estimate for compound 4 lay 1.9-fold (0.28 log units) above the measured number, and the stated range covers the measured number.
By their numbers in this assay, from the lowest: compounds 3, 4, 1 and 2 (each within the scatter of the next, the first and the last beyond it).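

In this assay, the change from methyl to dodecyl on this oxygen gives a 1.8-fold higher number from compound 3 to compound 4 (0.24 log units; within the scatter) and so stays within the scatter, even though it is the largest change in chain length in the set. Compound 4 also shows a 1.1-fold lower number from compound 1 to compound 4 (0.03 log units; within the scatter) and a 1.2-fold lower number from compound 2 to compound 4 (0.08 log units; within the scatter), so the dodecyl chain cannot be separated from the hexyl or 1-methylbutyl chain, and the numbers show no steady rise with chain length across compounds 3, 1 and 4. Among the compounds shown here, the only step beyond the scatter remains a 2.1-fold lower number from compound 2 to compound 3 (0.32 log units; beyond the scatter) and it is modest, which makes compound 2 the single compound that separates from methyl.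

Going by these compounds, whether a benzyl group, a carboxylic acid or an amine-bearing chain on this oxygen would separate clearly from methyl remains open. No measurement in hand bears on what lies behind these numbers.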